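The source may report more compounds than this note shows. Statements on the series, on what has been measured and on what is new or still open speak of the compounds shown alone.

Measured so far:
compound 1 `O=C(Nc1cccc(-n2cc(-c3ccncc3)c(-c3ccc(Cl)c(O)c3)n2)c1)Nc1cccc(C(F)(F)F)c1` — > 32500 nM
compound 2 `COc1cc(-c2nn(-c3cccc(NC(=O)Nc4cc(C(F)(F)F)cc(C(F)(F)F)c4)c3)cc2-c2ccncc2)ccc1Cl` — 1870 nM
compound 3 `COc1cc(-c2nn(-c3cccc(NC(=O)c4cccc(C(F)(F)F)c4)c3)cc2-c2ccncc2)ccc1Cl` — 17600 nM

In a functional assay on HCC 2998 cells (Homo sapiens) for inhibition, read by sulforhodamine B assay, with a stated time of 48 h (on this read-out lower numbers stand for stronger inhibition of growth and higher numbers for weaker inhibition of growth), compound 3 gives 17600 nM, the highest of the two numbers shown; compound 2 sits at 1870 nM, a gap beyond the scatter. Compound 1 reaches only a limit of this assay, > 32500 nM (the limit of > 32500 nM in this assay, at which 1 of the 3 values shown sits).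

Compound 4 `COc1cc(-c2nn(-c3cccc(NC(=O)Nc4ccc(Cl)c(Cl)c4)c3)cc2-c2ccncc2)ccc1Cl` follows compound 3 with one change: (3,4-dichlorophenyl)amino in place of 3-(trifluoromethyl)phenyl on a carbonyl carbon. For the measured compounds named here, no measured pair covers this change. Compound 4 is a urea, and compound 2, also a urea, shows the lower number, so a move to stronger inhibition of growth is expected, of moderate size given the new aryl group. The step of a 5.0-fold lower number from compound 3 to compound 4 (0.70 log units; beyond the scatter) is expected for compound 4 in this assay. Compound 4 is estimated at 3500 nM, within 1000 nM to 12000 nM.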

Compound 4, concentration for total growth inhibition: 6200 nM
Compound 4: middle estimate off by 1.8-fold (0.25 log units), on the low side; measured number inside the range.
By their numbers in this assay, from the lowest: compound 2; then compound 4; then compound 3. At a limit, above all of these: compound 1.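

In this assay, (3,4-dichlorophenyl)amino in place of 3-(trifluoromethyl)phenyl on the carbonyl carbon gives a 2.8-fold lower number from compound 3 to compound 4 (0.45 log units; beyond the scatter) and shows that this position responds to the swap. The swap brings in the amino nitrogen and the two chlorines together, and this single step cannot separate them. Nothing shown here accounts for the step. Still open, from the compounds shown here alone, is whether an aromatic ring is needed on this carbonyl carbon, for instance with a piperidine there. Also open, going by these compounds, is how 3-(trifluoromethyl)phenylamino on the core of compound 3 would compare.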